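The source may report more compounds than this note shows. Statements on the series, on what has been measured and on what is new or still open speak of the compounds shown alone.

Compound 2 `CCS(=O)(=O)Nc1cccc2c1CCCC2c1c[nH]cn1` gives 46.8 nM in an assay on isolated protein for binding affinity to Alpha-1A adrenergic receptor (Rattus norvegicus), read by radioligand binding (on this read-out higher numbers stand for weaker inhibition and lower numbers for stronger inhibition), the lowest of the three numbers seen. Compound 1 `O=S(=O)(Nc1cccc2c1CCCC2c1c[nH]cn1)C1CC1` gives 537 nM and compound 3 `CC(=O)Nc1cccc2c1CCCC2c1c[nH]cn1` gives 525 nM in this assay; the steps of an 11-fold lower number from compound 1 to compound 2 (1.06 log units; beyond the scatter) and an 11-fold higher number from compound 2 to compound 3 (1.05 log units; beyond the scatter) lie beyond the scatter, while a 1.0-fold lower number from compound 1 to compound 3 (0.01 log units; within the scatter) lies within it. Compound 4 `CCS(=O)(=O)Nc1cccc2c1CCCC2CNC` differs from compound 2 as follows: (methylamino)methyl in place of 1H-imidazol-4-yl on a saturated ring carbon. For the measured compounds named here, none of the measured steps touches this position; all three vary only the group on a nitrogen on an aromatic ring and keep the 1H-imidazol-4-yl. Going by the values given here, no measured step therefore bears on the change, and its size in this assay cannot be read from the series. Compound 4 is expected to give 400 nM, with a range from 40 nM to 4000 nM, a step of an 8.5-fold higher number from compound 2 to compound 4 (0.93 log units; beyond the scatter) taken as a rough expectation only.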

Compound 4, inhibition constant: 1380 nM
Compound 4: the middle estimate sits 3.5-fold (0.54 log units) below what was measured, and the stated range covers the measured number.
By their numbers in this assay, from the lowest: compound 2; then compounds 3 and 1 (each within the scatter of the next); then compound 4.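

For the compounds shown here, compound 4 shows that the position on the saturated ring carbon, untouched by the earlier steps, matters: (methylamino)methyl in place of 1H-imidazol-4-yl gives a 29-fold higher number from compound 2 to compound 4 (1.47 log units; beyond the scatter) in this assay and is the largest step. With no ring in this group, compound 4 still gives a measured number of 1380 nM in this assay rather than a limit. No evidence on the cause of this step is available.

As far as these compounds go, whether a pyridine ring or a primary aminomethyl at this carbon would read closer to compound 2 remains open. Also open, from the compounds shown here alone, is whether the ethylsulfonyl and acetyl groups would differ as before alongside (methylamino)methyl.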